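The source may hold more compounds than are shown below. What is called first, only, known or untested is meant among the compounds shown, and "the series" means these compounds.

For the measured compounds named here, compound 2 `C[C@@H](Nc1c(C(N)=O)cnc2ccc(C#N)cc12)c1ccc(Cl)cc1` has the lower of the two numbers measured so far in an assay on isolated protein for inhibition of phosphatidylinositol 4,5-bisphosphate 3-kinase catalytic subunit beta isoform (Homo sapiens), read by luminescence, with a stated time of 20 min; on this read-out higher numbers stand for weaker inhibition and lower numbers for stronger inhibition: compound 2 gives 139 nM, while compound 1 `CCC(CC)CNc1c(C(N)=O)cnc2ccc(C#N)cc12` gives 5740 nM, and the gap between these two values lies well beyond the usual scatter of repeated measurements. The two compounds differ from each other in more than one place, so that gap cannot be tied to any single structural change.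

Compound 3 `C[C@@H](Nc1c(C(N)=O)cnc2ccc(-c3cccnc3)cc12)c1ccc(Cl)cc1` has not yet been measured. It differs from compound 2 in exactly one place: pyridin-3-yl in place of cyano on an aromatic carbon. Everything else in the molecule is kept as in compound 2. Going by the values given here, nothing measured so far shows how this exchange behaves, so any expectation rests on the value of compound 2 alone and carries real uncertainty. A step of modest size toward stronger inhibition is expected, a 2.8-fold lower number from compound 2 to compound 3 (0.44 log units; beyond the scatter), although a result that stays within the scatter of compound 2 would not be surprising. For compound 3 in this assay the estimated value is 50 nM, with a range from 10 nM to 250 nM.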

Compound 3, half-maximal inhibitory concentration: 21 nM
For compound 3 the middle estimate is 2.4-fold (0.38 log units) above the measured one; measured number inside the range.
By their numbers in this assay, from the lowest: compound 3; then compound 2; then compound 1.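

For the compounds shown here, compound 2 and compound 3 form the first pair here that differs in only one place, so this is the first change that can be read on its own. In this assay, the exchange of cyano for pyridin-3-yl gives a 6.6-fold lower number from compound 2 to compound 3 (0.82 log units; beyond the scatter), showing that this aromatic carbon, meta to a fused ring and para to a fused ring, accepts a much larger group with 6 heavy atoms in place of 2 and that inhibition grows stronger, not weaker. The count of hydrogen-bond acceptors and the net charge stay the same across the exchange, while a six-membered aromatic ring is added, but no measurement here explains the gain.

The compounds shown leave open whether the ring nitrogen matters, since neither a plain phenyl ring nor pyridin-4-yl appears at this position, and a morpholine or a simple amine would test a different kind of group there. They also leave open whether the same exchange would help when the chain of compound 1 replaces the 1-(4-chlorophenyl)ethyl group of compound 3.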